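Swapping the sulfonyl aryl group in a series of EP3 ligands

A few compounds are considered here, and "the series" means these few. Any claim that something is new, unique, unknown or untested is made for them only; others in the source may bear on it.

Three compounds sharing one core have been characterised in an assay on isolated protein for displacement of a labelled ligand from prostaglandin E2 receptor EP3 subtype (Homo sapiens), read by scintillation counting, with a stated time of 2 h; on this read-out lower numbers stand for stronger inhibition and higher numbers for weaker inhibition. Compound 1 `Cc1nc(C)c(S(=O)(=O)NC(=O)NC/C=C2\CCCc3cnn(Cc4ccc(Cl)cc4Cl)c32)s1` gives 2 nM, the lowest number of the three. Compound 2 `O=C(NS(=O)(=O)c1ccc(Cl)cc1)OC/C=C1\CCCc2cnn(Cc3ccc(Cl)cc3Cl)c21` gives 11 nM, and compound 3 `O=C(NC/C(F)=C1\CCCc2cnn(C3CCN(c4ccc(F)cc4)CC3)c21)NS(=O)(=O)c1cc(Cl)c(Cl)s1` gives 13 nM; both of these stand beyond the scatter from compound 1, so compound 1 is the strongest binder among them.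

Compound 4 `COc1ccccc1S(=O)(=O)NC(=O)NC/C=C1\CCCc2cnn(Cc3ccc(Cl)cc3Cl)c21` differs from compound 1 in one place: 2-methoxyphenyl in place of 2,4-dimethyl-1,3-thiazol-5-yl on a sulfonyl sulfur. Within the data shown here, no measured pair isolates this exchange, so the size of the step rests on expectation alone. The related aryl sulfonyl groups in compound 2 and compound 3 still give low numbers, so compound 4 is expected to lose only modestly, with a 2.5-fold higher number from compound 1 to compound 4 (0.40 log units; beyond the scatter) as the estimated step. Compound 4 is expected to give about 5 nM, within a range from 1.5 nM to 20 nM.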

Compound 4, inhibition constant: 62 nM
Estimate against measurement, compound 4: 12-fold (1.09 log units) below; the measured number lies above the stated range.
By their numbers in this assay, from the lowest: compound 1; then compounds 2 and 3 (each within the scatter of the next); then compound 4.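

In this assay, among these compounds, the group on the sulfonyl sulfur proves to matter, with a 31-fold higher number from compound 1 to compound 4 (1.49 log units; beyond the scatter) as the only one-place step. The low numbers of the other aryl sulfonyl compounds therefore do not carry over to 2-methoxyphenyl on the core of compound 1. No measurement shown gives a reason for this step. Still open, as far as these compounds go, is whether the step follows the methoxy group or the change of ring. A plain phenyl group or an unmethylated thiazole on the same sulfonyl sulfur would separate the two.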